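The compounds below may be only part of what the source reports. "The series", "measured", "known", "first", "only" and "open" are said of these compounds alone.

Compound 1 `C=C(c1ccc(OC)cc1NC(=O)CO)c1ccc(OC)c2c1OC(C)(C)C=C2` and compound 2 `C=C(c1ccc(OC)cc1NC(=O)CO)c1ccc(OC)c2c1C=CC(C)(C)O2` are built from the same atoms joined differently; the difference between the two cores is not broken down here. In a functional assay on HeLa cells (Homo sapiens) for antiproliferative activity, read by MTT assay, with a stated time of 48 h (on this read-out lower numbers stand for stronger inhibition and higher numbers for weaker inhibition), compound 1 gives 40 nM, while compound 2 gives 100 nM. Compound 3 `C=C(c1ccc(OC)cc1NC(=O)CN)c1ccc(OC)c2c1OC(C)(C)C=C2` differs from compound 1 by amino in place of hydroxy on a saturated chain carbon bound to a carbonyl carbon, and in this assay compound 3 gives 120 nM. Compound 4 `C=C(c1ccc(OC)cc1NC(=O)CN)c1ccc(OC)c2c1C=CC(C)(C)O2` stands to compound 2 as compound 3 stands to compound 1: the change is amino in place of hydroxy on a saturated chain carbon bound to a carbonyl carbon, made on the core of compound 2, and the place reads the same in both pairs. For the measured compounds named here, the step from compound 2 to compound 4 in this assay is therefore expected to be a 3.0-fold higher number from compound 2 to compound 4 (0.48 log units; beyond the scatter), because a 3.0-fold higher number from compound 1 to compound 3 (0.48 log units; beyond the scatter) and only one such example exists. Compound 4 is estimated at 300 nM, expected to fall between 150 nM and 600 nM.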

Compound 4, half-maximal inhibitory concentration: 200 nM
The estimate for compound 4 lay 1.5-fold (0.18 log units) above the measured number, within the range that was stated.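

In this assay amino in place of hydroxy on the core of compound 2 gives a 2.0-fold higher number from compound 2 to compound 4 (0.30 log units; within the scatter) and, set beside the same change on the core of compound 1, the two steps do not differ: the same change on two cores in this assay, a 3.0-fold higher number (0.48 log units; beyond the scatter) from compound 1 to compound 3 and a 2.0-fold higher number (0.30 log units; within the scatter) from compound 2 to compound 4, 1.5-fold (0.18 log units) apart, within the scatter of two such steps.

On these two cores, then, the step carries over from one to the other within the scatter. For the compounds shown here, with only two pairs, this sets no rule for any other core and does not explain the size of the step.

The compounds shown leave open how other groups in this place would compare across the two cores, such as a dimethylamine, a carboxylic acid or a longer chain. From the compounds shown here alone, whether the match extends to other cores also remains open.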